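Ether side-chain variation in a receptor agonist series

This account rests on a few compounds, and the source may have more. Where it says the series, first, only, none or still open, it means among the compounds named here.

Compound 1 `Cc1nn(-c2ncnc3nc[nH]c23)c2c1C(OCc1ccccc1C#N)CC(=O)N2`: 8 nM
Compound 2 `Cc1nn(-c2ncnc3nc[nH]c23)c2c1C(C(=O)N(C)c1ccccc1)CC(=O)N2`: 32 nM

In a functional assay on HEK293 cells for agonist activity at G-protein coupled receptor 39 (Homo sapiens), read by scintillation proximity assay and inositol phosphate accumulation, with a stated time of 75 min, in the presence of a further agent that is not named here (on this read-out lower numbers stand for an effect already at smaller amounts and higher numbers for an effect only at larger amounts of compound), compound 1 gives 8 nM, the lowest of the two numbers, and compound 2 gives 32 nM. Among the compounds with values here, the only measured step, a 4.0-fold higher number from compound 1 to compound 2 (0.60 log units; beyond the scatter), touches the same saturated ring carbon but exchanges the whole ether for a carbamoyl group, so it bears only loosely on compound 3 `COc1ccc(CCOC2CC(=O)Nc3c2c(C)nn3-c2ncnc3nc[nH]c23)cc1`, which differs from compound 1 by 4-methoxybenzyl in place of 2-cyanophenyl on a saturated chain carbon bound to an oxygen on a saturated carbon. Within the data shown here, no measured step swaps one ether substituent for another. A step of modest size or none beyond the scatter is therefore expected, leaning toward a higher number. Compound 3 is estimated at 15 nM (range 5 nM to 50 nM). That estimate means an expected step of a 1.9-fold higher number from compound 1 to compound 3 (0.27 log units; within the scatter).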

Compound 3, half-maximal effective concentration: 2 nM
Compound 3: the middle estimate sits 7.5-fold (0.88 log units) above what was measured; the measured number lies below the stated range.
By their numbers in this assay, from the lowest: compound 3; then compound 1; then compound 2.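

Within the ether series, 4-methoxybenzyl in place of 2-cyanophenyl on a saturated chain carbon bound to an oxygen on a saturated carbon gives a 4.0-fold lower number from compound 1 to compound 3 (0.60 log units; beyond the scatter) in this assay. The nitrile of compound 1 is therefore not required for a low number, and a change confined to the ether side chain moves the value beyond the scatter. Nothing available explains this step.

This single change alters the chain and the ring substituents together, so their separate contributions remain unresolved. Also open, as far as these compounds go, is how an amine or a carboxylic acid in place of the methoxy group, or a longer chain, would read.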